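Replacing the 4-methoxyphenyl group on a shared core

The compounds below may be only part of what the source reports. "The series", "measured", "known", "first", "only" and "open" are said of these compounds alone.

In a functional assay on the whole organism (Hindlimb, strain albino) with Mus musculus as the target, in the maximal electroshock model, with a stated time of 0.5 h (a higher number here means that more compound is needed for the effect, a lower number that less compound is needed), compound 1 `CC(=O)N1N=C(Nc2nc3ccc(Cl)cc3s2)CC1c1ccc(O)cc1` gives 106 umol/kg and compound 2 `COc1ccc(C2CC(Nc3nc4ccc(Cl)cc4s3)=NN2C(C)=O)cc1` gives 93.3 umol/kg. These two values lie within the scatter of each other, so compound 2 stands level with compound 1. Compound 3 `CC(=O)N1N=C(Nc2nc3ccc(Cl)cc3s2)CC1OC1=CC=C1` keeps the core of compound 2 but changes the group on a saturated ring carbon: a group of 5 heavy atoms (4 carbon, 1 oxygen; one four-membered non-aromatic ring of carbon only) in place of a group of 8 heavy atoms (7 carbon, 1 oxygen; one six-membered aromatic ring of carbon only), on a saturated ring carbon. For the measured compounds named here, the only measured step, a 1.1-fold lower number from compound 1 to compound 2 (0.06 log units; within the scatter), put methyl in place of hydrogen on an oxygen and left the aromatic ring in place. Compound 3 loses that ring altogether, so this small step is a weak guide to a much larger change. With nothing firmer to go on, no shift beyond the scatter is expected, and the estimated step is a 1.2-fold higher number from compound 2 to compound 3 (0.07 log units; within the scatter). Compound 3 is expected at 110 umol/kg, with an estimated range from 40 umol/kg to 300 umol/kg.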

Compound 3, dose for half-maximal effect: 212 umol/kg
Estimate against measurement, compound 3: 1.9-fold (0.28 log units) below; low and high end bracket the measured number.
By their numbers in this assay, from the lowest: compounds 2, 1 and 3 (each within the scatter of the next, the first and the last beyond it).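

For the compounds shown here, the saturated ring carbon is sensitive to the group it carries: in this assay replacing the 4-methoxyphenyl group with the small four-membered carbon ring held through oxygen gives a 2.3-fold higher number from compound 2 to compound 3 (0.36 log units; beyond the scatter) and is the first step in this set to pass the scatter, though only modestly. Going by these compounds alone, the matching step from the other aromatic compound gives a 2.0-fold higher number from compound 1 to compound 3 (0.30 log units; within the scatter) and does not pass it, so the rise is clear in only one of the two comparisons. Nothing available explains this shift.

The compounds shown leave open whether the rise follows the loss of the aromatic ring or comes from the particular group that entered. A plain phenyl ring, a simple methoxy group or an amine on the same carbon would help separate these two readings.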